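This account rests on a few compounds, and the source may have more. Where it says the series, first, only, none or still open, it means among the compounds named here.

Compound 1 `Cc1ccc2nc(/N=C3\C(=O)N(CN(c4ccccc4)c4ccccc4)c4cccc(Br)c43)sc2c1` was tested in an ADME assay on 184B5 cells (Homo sapiens) for cytotoxicity, read by sulforhodamine B assay, with a stated time of 48 h (on this read-out higher numbers stand for weaker inhibition of growth and lower numbers for stronger inhibition of growth), where compound 1 gives 70300 nM. Two simpler compounds share part of its make-up: compound 2 `O=C1C(=O)N(CN2CCCCC2)c2cccc(Br)c21`, which in this assay gives 85200 nM, and compound 3 `O=C1C(=O)N(CN2CCCCC2)c2cccc(Cl)c21`, which gives 93700 nM. The change between them, (chloro in place of bromo on an aromatic carbon), made a 1.1-fold higher number from compound 2 to compound 3 (0.04 log units; within the scatter). How the core of compound 1 differs from the core of compound 2 is not broken down here. Compound 4 `Cc1ccc2nc(/N=C3\C(=O)N(CN(c4ccccc4)c4ccccc4)c4cccc(Cl)c43)sc2c1` carries the same change made on compound 1: chloro in place of bromo on an aromatic carbon. Since the place of the change is the same as in the measured pair, the step from compound 1 to compound 4 is expected to be a 1.1-fold higher number from compound 1 to compound 4 (0.04 log units; within the scatter), resting on a 1.1-fold higher number from compound 2 to compound 3 (0.04 log units; within the scatter). Compound 4 is therefore estimated at 77000 nM, expected to lie between 45000 nM and 130000 nM.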

Compound 4, concentration for 50% growth inhibition: 67800 nM
Compound 4: middle estimate off by 1.1-fold (0.06 log units), on the high side, within the range that was stated.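

In this assay, putting chloro in place of bromo on the core of compound 1 gave a 1.0-fold lower number from compound 1 to compound 4 (0.02 log units; within the scatter). Set beside the earlier pair, the change carried over from one core to the other without a detectable difference: the same change on two cores in this assay, a 1.1-fold higher number (0.04 log units; within the scatter) from compound 2 to compound 3 and a 1.0-fold lower number (0.02 log units; within the scatter) from compound 1 to compound 4, 1.1-fold (0.06 log units) apart, within the scatter of two such steps. This shows that on these two cores the swap leaves the number within the scatter, but it gives no direction for the change and says nothing about other cores or other cell lines.

Only bromo and chloro are shown on this aromatic carbon, so what a methoxy group, an amine or a carboxylic acid would do there stays open. Going by these compounds, it is also open whether such larger changes would carry between the two cores as faithfully.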